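Butoxy in Place of Benzyl: an Expected Shift in Growth Inhibition

The source may report more compounds than this note shows. Statements on the series, on what has been measured and on what is new or still open speak of the compounds shown alone.

Two numbers and one limit make up what is known so far. In a functional assay on SNB-75 cells (Homo sapiens) for inhibition, read by sulforhodamine B assay, with a stated time of 48 h (on this read-out higher numbers stand for weaker inhibition of growth and lower numbers for stronger inhibition of growth), compound 2 `Nc1nn(C(=O)Nc2ccc(Cc3ccccc3)cc2)c2ccccc12` gives 17000 nM, the lowest of the two numbers obtained. Compound 1 `O=C(Nc1ccc(Cc2ccccc2)cc1)Nc1nn(C(=O)Nc2ccc(Cc3ccccc3)cc2)c2ccccc12` gives 33800 nM in this assay, a value that lies within the scatter of the result for compound 2, so no order between the two can be stated. Compound 3 `COc1ccc(NC(=O)Nc2n[nH]c3ccccc23)cc1` is a separate case: its result is a limit of the assay, > 100000 nM, and no number stands for it. That result is the limit of > 100000 nM in this assay, at which 1 of the 3 values shown sits.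

Compound 4 `CCCCOc1ccc(NC(=O)n2nc(N)c3ccccc32)cc1` has not yet been measured. It differs from compound 2 in one place: butoxy in place of benzyl on an aromatic carbon. Among the compounds with values here, no measured pair spans this change, so its size is open. The account expects a modest weakening of growth inhibition, going beyond the scatter, as the step of a 2.4-fold higher number from compound 2 to compound 4 (0.37 log units; beyond the scatter) in this assay. On that basis compound 4 is estimated at 40000 nM in this assay, with a range from 12000 nM to 100000 nM.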

Compound 4, concentration for 50% growth inhibition: 28600 nM
Compound 4: middle estimate off by 1.4-fold (0.15 log units), on the high side; the range from low to high includes it.
By their numbers in this assay, from the lowest: compounds 2, 4 and 1 (each within the scatter of the next). At a limit, above all of these: compound 3.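

In this assay, within the data shown here, the exchange shows a 1.7-fold higher number from compound 2 to compound 4 (0.23 log units; within the scatter) and so puts a measured size on a change that no earlier pair spanned. At this position, on an aromatic carbon para to a large group, a six-membered aromatic ring of carbon only can thus leave with the chain of butoxy entering, and the read-out does not separate compound 2 from compound 4. No measurement shown here bears on the cause of this outcome.

Open, on these data alone, is whether a longer chain, a shorter one such as methoxy, or an amine at this position would also stay within the scatter of compound 2. Also open, as far as these compounds go, is whether butoxy in place of benzyl on compound 1 would read the same way.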